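A few compounds are considered here, and "the series" means these few. Any claim that something is new, unique, unknown or untested is made for them only; others in the source may bear on it.

The measured compounds and their results:

compound 1, `Cc1ccc(NC(=O)C2CCN(C/C=C/c3ccccc3)CC2)cc1`: 33900 nM
compound 2, `CCc1ccc(NC(=O)C2CCN(C/C=C/c3ccccc3)CC2)cc1`: 23300 nM
compound 3, `O=C(Nc1cccc(Cl)c1)C1CCN(C/C=C/c2ccccc2)CC1`: 20000 nM

In a functional assay on HepG2 cells (Homo sapiens) for inhibition, read by MTT assay, with a stated time of 72 h (on this read-out higher numbers stand for weaker inhibition and lower numbers for stronger inhibition), compound 1 gives 33900 nM, the highest of the three numbers, though all three sit within the scatter of one another. The step of a 1.5-fold lower number from compound 1 to compound 2 (0.16 log units; within the scatter) and the step of a 1.7-fold lower number from compound 1 to compound 3 (0.23 log units; within the scatter) both stay inside the usual spread of repeated measurements, as does the step of a 1.2-fold lower number from compound 2 to compound 3 (0.07 log units; within the scatter). Nothing among these three compounds moves beyond the scatter.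

Compound 4, `O=C(Nc1nccs1)C1CCN(C/C=C/c2ccccc2)CC1`, is the next compound to be tested. It differs from compound 1 by 1,3-thiazol-2-yl in place of 4-methylphenyl on an amide-type nitrogen. Among the compounds with values here, of the measured steps, the one from compound 1 to compound 3 is the closest relative, since it also exchanges the group on the amide-type nitrogen, and it is within the scatter; the step to compound 2 alters only the attached saturated chain and is within the scatter too. Within the data shown here, none of the measured compounds carries a five-membered aromatic ring with hetero atoms at this place, so the change in compound 4 is not directly covered. On this basis no step beyond the scatter is expected in this assay, with the outcome uncertain in direction. The expected step is a 1.5-fold lower number from compound 1 to compound 4 (0.19 log units; within the scatter). For compound 4 the estimate is 22000 nM, with a likely range from 6000 nM to 70000 nM.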

Compound 4, half-maximal inhibitory concentration: 22400 nM
Compound 4: the middle estimate sits 1.0-fold (0.01 log units) below what was measured; measured number inside the range.
By their numbers in this assay, from the lowest: compounds 3, 4, 2 and 1 (each within the scatter of the next).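

In this assay, the step from a six-membered aromatic ring of carbon only to a five-membered aromatic ring with hetero atoms on the amide-type nitrogen gives a 1.5-fold lower number from compound 1 to compound 4 (0.18 log units; within the scatter). Set against the other two aryl groups, 1,3-thiazol-2-yl gives a 1.1-fold higher number from compound 3 to compound 4 (0.05 log units; within the scatter) and a 1.0-fold lower number from compound 2 to compound 4 (0.02 log units; within the scatter), so this place now holds a ring of a different size and atom make-up, and the number still stays within the scatter of all three earlier compounds, which carried only substituted phenyl rings there. Nothing measured here bears on why the number stays put after this exchange.

The compounds shown leave open whether a cyclohexyl group or a pyridin-2-yl ring on the amide-type nitrogen, or an amine or a carboxylic acid carried on the aromatic ring at that place, would move the number beyond the scatter. With every step shown lying within the scatter, they also leave open whether any change at this place, or elsewhere on the shared core, affects the number at all.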